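The source may hold more compounds than are shown below. What is called first, only, known or untested is meant among the compounds shown, and "the series" means these compounds.

Measured in a functional assay on HCT-116 cells (Homo sapiens) for inhibition, read by MTT assay, with a stated time of 48 h; a lower number here means a stronger inhibitor, a higher number a weaker inhibitor:
- Compound 1 `O=C(O)c1ccc2c(c1)no[n+]2[O-]`: 55800 nM
- Compound 2 `O=C(CCCCOC(=O)c1ccc2c(c1)no[n+]2[O-])NO`: 2630 nM

Of these two compounds, compound 2 has the lower number, at 2630 nM, and its gap to compound 1 lies beyond the usual scatter. Compound 3 `O=C(CCCCCCOC(=O)c1ccc2c(c1)no[n+]2[O-])NO` has not yet been measured in this assay. It differs from compound 2 by one change: 2-(hydroxycarbamoyl)ethyl in place of hydroxycarbamoyl on a saturated chain carbon, four bonds along the chain from an oxygen next to a carbonyl group. Put simply, 2-(hydroxycarbamoyl)ethyl stands in place of hydroxycarbamoyl on a saturated chain carbon, four bonds along the chain from an oxygen next to a carbonyl group.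

Within the data shown here, no measured pair of compounds isolates a change of this kind, so the data offer no direct guide to its size. A modest move towards a lower number is expected, though it may not clear the scatter. The expected change is a 2.2-fold lower number from compound 2 to compound 3 (0.34 log units; beyond the scatter). For compound 3 the estimated value is 1200 nM, with an expected range of 300 nM to 4000 nM.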

Compound 3, half-maximal inhibitory concentration: 1090 nM
Estimate against measurement, compound 3: 1.1-fold (0.04 log units) above; the range from low to high includes it.
By their numbers in this assay, from the lowest: compound 3; then compound 2; then compound 1.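

At the saturated chain carbon, four bonds along the chain from an oxygen next to a carbonyl group, putting 2-(hydroxycarbamoyl)ethyl in place of hydroxycarbamoyl gives in this assay a 2.4-fold lower number from compound 2 to compound 3 (0.38 log units; beyond the scatter), a modest step. Among these compounds, this is the first measured change that sits in a single place, as compound 1 and compound 2 differ by more than one change and could say nothing about this position on its own. It shows that the larger 2-(hydroxycarbamoyl)ethyl group is accepted here and that the number moves down rather than up, but the compounds carry no measured information that would explain the step.

With a single step on this chain, the compounds shown cannot say whether a longer chain would lower the number further, hold it or turn it back up. On these data alone, it also remains open whether the number would hold if an amine or a primary amide stood at the end of the chain in place of the hydroxycarbamoyl group.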